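Swapping a phenyl for a benzyl on the piperazine nitrogen

A few compounds are considered here, and "the series" means these few. Any claim that something is new, unique, unknown or untested is made for them only; others in the source may bear on it.

Measured compounds:
- compound 1, `CCN1CCN(CC(=O)Nc2ccc(-c3nc(-c4ccccc4)c(-c4ccccc4)n3C)cc2)CC1`: 32.8%
- compound 2, `CN(C)/C=C/N1CCN(CC(=O)Nc2ccc(-c3nc(-c4ccccc4)c(-c4ccccc4)n3C)cc2)CC1`: 19.4%
- compound 3, `Cn1c(-c2ccc(NC(=O)CN3CCN(c4ccccc4)CC3)cc2)nc(-c2ccccc2)c1-c1ccccc1`: 59.6%

In a functional assay on MCF7 cells (Homo sapiens) for cytotoxicity, read by MTT assay, with a stated time of 24 h, tested at 16 ug/mL (on this read-out lower numbers stand for a weaker effect and higher numbers for a stronger effect at the one concentration tested), compound 3 gives 59.6%, the highest of the three numbers, with compound 1 nearest and compound 2 furthest below it, both gaps beyond the scatter. Compound 4, `Cn1c(-c2ccc(NC(=O)CN3CCN(Cc4ccccc4)CC3)cc2)nc(-c2ccccc2)c1-c1ccccc1`, has not been measured. It differs from compound 3 in one place: benzyl in place of phenyl on an amine nitrogen in a ring.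

Going by the values given here, two measured steps bear on this change, both ending at the phenyl of compound 3: a number 26.8 percentage points higher from compound 1 to compound 3 (beyond the scatter) and a number 40.2 percentage points higher from compound 2 to compound 3 (beyond the scatter). Each shows that placing a phenyl on this ring nitrogen gave a clearly higher read-out than a non-aromatic group there. Among the compounds with values here, compound 4 keeps an aromatic ring but sets it one carbon away from the nitrogen, a situation no measured compound covers, so the expected step is a moderate decrease with wide uncertainty: a number 14.6 percentage points lower from compound 3 to compound 4 (beyond the scatter). Compound 4 is therefore estimated at 45%, within a range of 25% to 65%.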

Compound 4, a percentage reported as activity, at one concentration (the size of the read-out at that concentration, not a potency): 28.3%
The estimate for compound 4 lay 16.7 percentage points above the measured number; measured number inside the range.
By their numbers in this assay, from the lowest: compounds 2, 4 and 1 (each within the scatter of the next, the first and the last beyond it); then compound 3.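

Benzyl and phenyl carry the same six-membered aromatic ring, yet exchanging one for the other on this amine nitrogen removes most of the advantage seen with phenyl in this assay (a number 31.3 percentage points lower from compound 3 to compound 4 (beyond the scatter)). An aromatic ring in the substituent is therefore not enough on its own, as compound 4 stays within the scatter of both non-aromatic examples (a number 8.9 percentage points higher from compound 2 to compound 4 (within the scatter); a number 4.5 percentage points lower from compound 1 to compound 4 (within the scatter)). No measurement shown explains why the phenyl and benzyl groups differ so sharply.

A longer chain ending in phenyl, such as 2-phenylethyl, could show whether the read-out keeps falling or levels off as the ring moves farther from the nitrogen. Also open, on these data alone, is how a phenyl carrying a fluorine or a methoxy group would compare with the unsubstituted phenyl of compound 3.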